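This account rests on a few compounds, and the source may have more. Where it says the series, first, only, none or still open, it means among the compounds named here.

Of the compounds shown here, three have been tested in a functional assay on A-375 cells (Homo sapiens) for cytotoxicity, read by MTT assay, with a stated time of 72 h, tested at 100 uM; on this read-out lower numbers stand for less inhibition of growth and higher numbers for more inhibition of growth at the one concentration tested. Compound 1 `Cc1ccnc(/C(N)=N/NC(=S)N2CCCC2)c1` gives 88.8%, compound 2 `Cc1ccnc(/C(N)=N/NC(=S)N2CCCCCC2)c1` gives 77%, and compound 3 `N/C(=N\NC(=S)N1CCN(c2ccccn2)CC1)c1ccc(F)cn1` gives 76.2%. Among these three numbers compound 3 stands lowest; its value lies within the usual scatter of that of compound 2, so the two cannot be told apart, while the number of compound 1 lies beyond the scatter above it. Compound 4 `Cc1cccc(/C(N)=N/NC(=S)N2CCN(c3ccccn3)CC2)n1` has not yet been measured. It differs from compound 3 in one place: 6-methylpyridin-2-yl in place of 5-fluoropyridin-2-yl on a carbon with a double bond to nitrogen. Among the measured compounds shown here, no step between two measured compounds that differ in a single place is available, so the size of this change can only be judged from the structures themselves. For the measured compounds named here, as only one group on one ring is exchanged for another of the same size, a step within the scatter of this assay seems the most likely outcome, with no clear direction. Compound 4 is therefore expected to give about 78% in this assay, between 62% and 92%, an expected step of a number 1.8 percentage points higher from compound 3 to compound 4 (within the scatter) that stays within the scatter.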

Compound 4, percent growth inhibition at one concentration: 83.8%
Beside the measured number, compound 4's estimate is 5.8 percentage points below it; measured number inside the range.
By their numbers in this assay, from the lowest: compounds 3, 2, 4 and 1 (each within the scatter of the next, the first and the last beyond it).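

Among the compounds shown here, this is the first measured step between two compounds that differ in one place: with 6-methylpyridin-2-yl in place of 5-fluoropyridin-2-yl on a carbon with a double bond to nitrogen, this assay gives a number 7.6 percentage points higher from compound 3 to compound 4 (within the scatter), so the two compounds cannot be told apart. At this place, then, a methyl-bearing ring can stand in for a fluorine-bearing ring of the same size with no change that this read-out can resolve at its one concentration. No measurement at hand offers an explanation for this result.

The compounds shown leave open whether a larger change at this place, such as a pyridine ring bearing an amine or a carboxylic acid, or a plain phenyl ring, would move the number beyond the scatter. They also leave open whether compound 3 and compound 4 would still match at lower concentrations.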